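The source may hold more compounds than are shown below. What is called first, only, known or untested is meant among the compounds shown, and "the series" means these compounds.

Measured so far, in a functional assay for inhibition, with Homo sapiens as the target; on this read-out lower numbers stand for stronger inhibition and higher numbers for weaker inhibition:

compound 1 `C=CCn1ncc2cnc(Cc3ccccc3)n2c1=O`: > 48000 nM
compound 2 `C=CCn1ncc2cnc(COC)n2c1=O`: > 48000 nM
compound 3 `COCc1nc(Br)c2cnnc(O)n12`: > 48000 nM

In this assay compound 1 gives > 48000 nM, which is a limit of the assay and not a number. Compound 2 likewise gives > 48000 nM, again a limit. Compound 3 gives > 48000 nM, also a limit. Compound 1 and compound 2 share a core and differ in one place: phenyl in place of methoxy on a saturated chain carbon bound to an aromatic carbon. The step that the two limits leave unreadable from compound 2 to compound 1 is therefore not readable, because of the limit of > 48000 nM in this assay, at which 3 of the 3 values shown sit.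

Compound 4 `Oc1nncc2c(Br)nc(Cc3ccccc3)n12` has not yet been measured. It stands to compound 3 as compound 1 stands to compound 2, by the same change: phenyl in place of methoxy on a saturated chain carbon bound to an aromatic carbon. How the core of compound 3 differs from the core of compound 2 is not broken down here.

For the measured compounds named here, since every value so far is a limit, the step from compound 3 to compound 4 is expected to be a number no higher from compound 3 to compound 4 (the limit leaves the size open), resting on the fact that (the limit of > 48000 nM in this assay, at which 3 of the 3 values shown sit). Compound 4 is therefore expected at about 48000 nM, most likely again as a limit, with a range from 15000 nM to 150000 nM.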

Compound 4, half-maximal inhibitory concentration: > 48000 nM
Compound 4: a limit, no number (the forecaster's own chance of this, stated with the estimate: 80%); the middle value lies on the limit itself.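

In this assay compound 4 gives > 48000 nM, which is a limit and not a number. No size can be read for the change from compound 3 to compound 4, because both compounds sit at the same limit: the limit of > 48000 nM in this assay, at which 4 of the 4 values shown sit. The compounds shown leave open how strongly any of them inhibits, and whether phenyl in place of methoxy alters inhibition at all.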